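Swapping Ethoxy for Methylsulfonyl: What Cytotoxicity to Expect

A few compounds are considered here, and "the series" means these few. Any claim that something is new, unique, unknown or untested is made for them only; others in the source may bear on it.

Compound 2 `CCOc1cccc(-c2ccc(C(=O)N(Cc3cccc(OCCCCCC(=O)O)c3)C(C)C)cc2)c1` is one of three compounds tested in an ADME assay on Raji cells (Homo sapiens) for cytotoxicity, read by CellTiter-Glo and resazurin assay, with a stated time of 72 h; a lower number here means that less compound is needed, a higher number that more compound is needed for the effect. Compound 2 gives > 20800 nM, which is a limit of the assay rather than a number. Compound 1 `CC(C)COc1cccc(-c2ccc(C(=O)N(Cc3cccc(OCCCCCC(=O)O)c3)C(C)C)cc2)c1` gives > 26000 nM, also a limit. Compound 3 `CC(C)N(Cc1cccc(OCCCCCC(=O)O)c1)C(=O)c1ccc(-c2cc3ccccc3n2S(=O)(=O)c2ccccc2)cc1` gives > 26000 nM, again a limit. For the measured compounds named here, the only measured step, a step that the two limits leave unreadable from compound 1 to compound 2, sits between two limits and yields no size. Compound 4 `CC(C)N(Cc1cccc(OCCCCCC(=O)O)c1)C(=O)c1ccc(-c2cccc(S(C)(=O)=O)c2)cc1` differs from compound 2 by methylsulfonyl in place of ethoxy on an aromatic carbon. Going by the values given here, no measured step bears on this change, and all three values rest at limits, the limit of > 20800 nM in this assay, at which 1 of the 3 values shown sits, and (the limit of > 26000 nM in this assay, at which 2 of the 3 values shown sit), so no direction beyond the scatter can be drawn. Compound 4 is expected to give 30000 nM, between 15000 nM and 60000 nM. This corresponds to an expected step that the limit leaves unreadable from compound 2 to compound 4 in this assay.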

Compound 4, half-maximal effective concentration: > 26000 nM
Compound 4: only a limit was reported; the forecaster's own chance of this, stated with the estimate: 85%; the middle value does not contradict the limit.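

The steps from compound 1 and from compound 2 to compound 4 cannot be read, as each joins two limits. The compounds shown leave open what concentration any of them needs for the effect, and whether methylsulfonyl in place of ethoxy changes it.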